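The source may report more compounds than this note shows. Statements on the series, on what has been measured and on what is new or still open speak of the compounds shown alone.

Measured compounds:
Compound 1 `Cc1cc(-c2ccc(C(F)(F)F)cc2)nn1S(=O)(=O)Oc1ccccc1` in a functional assay on the whole organism for inhibition, with Mus musculus as the target, in the writhing test, with stated times of 3 days and 20 min, at a dose of 30 mg/kg by the oral route (a lower number here means less inhibition, a higher number more inhibition at the dose given (going by the name of the read-out)), gives 25.8%.
Compound 2 `Cc1cccc(-c2cc(C)n(S(=O)(=O)Oc3ccccc3)n2)c1` in this assay gives 43.8%.

Compound 2 stands highest of the two numbers shown; its nearest neighbour, compound 1, lies lower by a gap that goes beyond the usual scatter of this kind of measurement. Compound 3 `Cc1cc(-c2ccco2)nn1S(=O)(=O)Oc1ccccc1` has not yet been measured in this assay. It differs from compound 2 in one place: furan-2-yl in place of 3-methylphenyl on an aromatic carbon. A five-membered aromatic ring with one hetero atom thus takes the place of a six-membered aromatic ring of carbon only, with the rest of the shared core unchanged.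

Among the compounds with values here, no pair of measured compounds shows this kind of exchange, so the size of the step rests on judgement alone. A moderate fall beyond the scatter is expected, on the reasoning that both measured values sit well apart and the smaller ring is an untested departure from compound 2, whose value is 43.8%. Compound 3 is therefore estimated at 30%, with a range from 15% to 48%, which corresponds to an expected step of a number 13.8 percentage points lower from compound 2 to compound 3 (beyond the scatter).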

Compound 3, a percentage reported as inhibition, in the whole organism at one dose (the size of the read-out at that dose, not a potency): 42.5%
Compound 3: the middle estimate sits 12.5 percentage points below what was measured; the measured number falls inside the stated range.
By their numbers in this assay, from the lowest: compound 1; then compounds 3 and 2 (each within the scatter of the next).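

In this assay, replacing 3-methylphenyl with furan-2-yl on this aromatic carbon gives a number 1.3 percentage points lower from compound 2 to compound 3 (within the scatter). At this position, therefore, the read-out does not separate a six-membered aromatic ring of carbon only from a five-membered aromatic ring with one hetero atom, even though the entering group has fewer heavy atoms and adds a hydrogen-bond acceptor. The information at hand offers no measured basis for explaining this result.

As far as these compounds go, it remains open whether a thiophen-2-yl group, a saturated ring such as cyclohexyl, an amine or a longer chain such as n-butyl would give a similar reading on this carbon. A single oral dose also leaves open how compound 2 and compound 3 would compare across a range of doses.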